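A few compounds are considered here, and "the series" means these few. Any claim that something is new, unique, unknown or untested is made for them only; others in the source may bear on it.

Working notes on the series. In an assay on isolated protein for inhibition of leukotriene A-4 hydrolase (Homo sapiens) (a higher number here means a weaker inhibitor, a lower number a stronger inhibitor), compound 1 `Cc1ccc(-c2csc(=N)n2CC(=O)N2CCN(c3ccccc3)CC2)cc1` gives 4290 nM, and compound 2 `N=c1scc(-c2ccccc2)n1CC(=O)N1CCOCC1` gives 8650 nM; the two numbers lie within the scatter of each other, so no order between them is claimed. Compound 3 `Cc1ccc(-c2csc(=N)n2CC(=O)N2CCN(C)CC2)cc1` is not yet measured in this assay; it differs from compound 1 by methyl in place of phenyl on an amine nitrogen in a ring. Within the data shown here, no measured pair shows this change, so the size of the step is open; a modest loss is expected rather than a gain. For compound 3 the expected value in this assay is 9000 nM, with a range from 2500 nM to 35000 nM, which means an estimated step of a 2.1-fold higher number from compound 1 to compound 3 (0.32 log units; beyond the scatter).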

Compound 3, inhibition constant: 369 nM
Estimate against measurement, compound 3: 24-fold (1.39 log units) above, and the stated range ends above it.
By their numbers in this assay, from the lowest: compound 3; then compounds 1 and 2 (each within the scatter of the next).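

In this assay, methyl in place of phenyl on the amine nitrogen in the ring gives a 12-fold lower number from compound 1 to compound 3 (1.07 log units; beyond the scatter), so the group at this position strongly affects the number, and a phenyl there is not required for inhibition. Nothing available bears on the origin of this step. The compounds shown leave open whether a hydrogen, an ethyl group or a longer chain on that nitrogen would give a lower or higher number than methyl. Also open, going by these compounds, is how a benzyl group or an acetyl group there would compare.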